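The source may hold more compounds than are shown below. What is called first, only, known or untested is meant among the compounds shown, and "the series" means these compounds.

Compound 1, `Fc1cccc(F)c1Cn1ccc2nc(-c3c(F)cccc3F)nc-2c1`, gives in an ADME assay on MDBK cells (Bos taurus) for cytotoxicity (on this read-out lower numbers stand for higher toxicity in this test and higher numbers for lower toxicity in this test), only the assay limit of > 100000 nM.
Compound 2, `Fc1cccc(F)c1-c1nc2ccn(Cc3ccccc3)cc-2n1`, gives only the assay limit of > 100000 nM.
Compound 3, `Fc1cccc(Cn2ccc3nc(-c4ccccc4)nc-3c2)c1`, gives only the assay limit of > 100000 nM.

Compound 3 therefore stands at the limit, as do the other two values shown (the limit of > 100000 nM in this assay, at which 3 of the 3 values shown sit). Within the data shown here, the single measured step, a step that the two limits leave unreadable from compound 1 to compound 2, is unreadable, so no measured step gives a readable size for a change on this position. Compound 4, `CCC(CC)Cn1ccc2nc(-c3ccccc3)nc-2c1`, differs from compound 3 by pentan-3-yl in place of 3-fluorophenyl on a saturated chain carbon bound to an aromatic nitrogen. With every shown value at the limit, compound 4 is expected to remain there as well, the expected step being a number no higher from compound 3 to compound 4 (the limit leaves the size open). Compound 4 is estimated at 100000 nM, within a range from 30000 nM to 300000 nM.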

Compound 4, half-maximal cytotoxic concentration: > 100000 nM
Compound 4: a limit, no number; the forecaster's own chance of this, stated with the estimate: 75%; the middle value sits exactly at the limit.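

Compound 3 and compound 4 both give only a limit, so the step between them cannot be read. The compounds shown leave open at what concentration any of them would become cytotoxic, with every value a limit: the limit of > 100000 nM in this assay, at which 4 of the 4 values shown sit.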